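The compounds below may be only part of what the source reports. "The series", "measured", "known", "first", "only" and "open" are said of these compounds alone.

Compound 1 `CCC1c2cc(Cl)ccc2C(=O)N1c1cccnc1` is the reference of the series. In an ADME assay on microsomes from liver (Homo sapiens) for metabolic stability, read by LC-MS, using NADPH, with stated times of 10 min and 30 min (a higher number here means faster removal of the compound, a lower number slower removal), compound 1 gives 6.6 mL/min/kg. Compound 2 `CC1c2cc(Cl)ccc2C(=O)N1c1cccnc1` carries the change (hydrogen in place of methyl on a saturated chain carbon bound to a saturated ring carbon), and in this assay compound 2 gives 12.2 mL/min/kg, a step of a 1.8-fold higher number from compound 1 to compound 2 (0.27 log units; within the scatter). Compound 3 `CCC(=O)N[C@@H]1CCCc2c1cncc2N1C(=O)c2ccc(Cl)cc2[C@H]1CC` has a different core; the difference between the two cores is not broken down here. In this assay compound 3 returns only a limit, < 3.5 mL/min/kg, at the limit of < 3.5 mL/min/kg in this assay, at which 1 of the 3 values shown sits. Compound 4 `CCC(=O)N[C@@H]1CCCc2c1cncc2N1C(=O)c2ccc(Cl)cc2[C@H]1C` is compound 3 with the same change, (hydrogen in place of methyl on a saturated chain carbon bound to a saturated ring carbon). The step expected from compound 3 to compound 4 in this assay is an at least 1.4-fold higher number from compound 3 to compound 4 (0.15 log units; that floor lies within the scatter), resting on a 1.8-fold higher number from compound 1 to compound 2 (0.27 log units; within the scatter), though the starting point of compound 3 is a limit rather than a number, so the move may stay under the limit. Compound 4 is estimated at 5 mL/min/kg in this assay, between 2.5 mL/min/kg and 10 mL/min/kg.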

Compound 4, clearance: < 3.5 mL/min/kg
Compound 4: a limit, no number; the forecaster's own chance of this, stated with the estimate: 40%; middle value at least 1.4-fold (0.15 log units) from the limit.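

Compound 3 and compound 4 each return only a limit, so no step can be read between them: the limit of < 3.5 mL/min/kg in this assay, at which 2 of the 4 values shown sit. Going by these compounds, what stays open is how far ethyl to methyl shifts clearance on the core shared by compound 3 and compound 4.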